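From cyclopropyl to tert-butyl on the amide of compound 1

The compounds below may be only part of what the source reports. "The series", "measured", "known", "first", "only" and "open" are said of these compounds alone.

Compound 1 `O=C(C1CC1)N1CCN(c2nc(=O)c3cc(C(F)(F)F)cc([N+](=O)[O-])c3s2)CC1` is the most soluble of the three measured compounds: in a physicochemical assay for solubility, read by HPLC (a lower number here means a less soluble compound, a higher number a more soluble compound), compound 1 gives 52.9 ug/mL. Compound 2 `O=C(c1ccc(F)cc1)N1CCN(c2nc(=O)c3cc(C(F)(F)F)cc([N+](=O)[O-])c3s2)CC1` gives 1.69 ug/mL and compound 3 `Cc1ccc(C(=O)N2CCN(c3nc(=O)c4cc(C(F)(F)F)cc([N+](=O)[O-])c4s3)CC2)cc1` gives 6.7 ug/mL; the steps of a 31-fold lower number from compound 1 to compound 2 (1.50 log units; beyond the scatter) and a 7.9-fold lower number from compound 1 to compound 3 (0.90 log units; beyond the scatter) show that both replacements of the cyclopropyl group lowered the number clearly. Compound 4 `CC(C)(C)C(=O)N1CCN(c2nc(=O)c3cc(C(F)(F)F)cc([N+](=O)[O-])c3s2)CC1` changes the same spot in another way: tert-butyl in place of cyclopropyl on a carbonyl carbon. The two measured steps put an aromatic ring in place of cyclopropyl, whereas tert-butyl has no ring, so those steps guide only loosely and a smaller drop is expected here. Compound 4 is estimated at 22 ug/mL, between 7 ug/mL and 55 ug/mL, a step of a 2.4-fold lower number from compound 1 to compound 4 (0.38 log units; beyond the scatter) expected to remain modest.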

Compound 4, solubility: 5.87 ug/mL
Compound 4: the middle estimate sits 3.7-fold (0.57 log units) above what was measured, outside the stated range (below it).
By their numbers in this assay, from the lowest: compound 2; then compounds 4 and 3 (each within the scatter of the next); then compound 1.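

In this assay, the fall seen with the aromatic rings also appears with a group that has no ring at all: the step is a 9.0-fold lower number from compound 1 to compound 4 (0.95 log units; beyond the scatter). Tert-butyl matches 4-methylphenyl at this carbonyl carbon, with a 1.1-fold lower number from compound 3 to compound 4 (0.06 log units; within the scatter), but still differs from 4-fluorophenyl, with a 3.5-fold higher number from compound 2 to compound 4 (0.54 log units; beyond the scatter). No measurement at hand explains why cyclopropyl stands apart from all three replacements.

The compounds shown leave open how a straight propyl chain, an amine or a carboxylic acid at this carbonyl carbon would compare with cyclopropyl.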